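The compounds below may be only part of what the source reports. "The series", "measured", "known", "first", "only" and "open" are said of these compounds alone.

Working notes on the series. Compound 1 `Cc1cc(Cl)c(NC(=O)N(Cc2ccc(Oc3ccc(F)cc3)cc2)C2CCCCCC2)c(Cl)n1` in an assay for inhibition of acyl-CoA:cholesterol acyltransferase (Oryctolagus cuniculus), using microsomes (on this read-out lower numbers stand for stronger inhibition and higher numbers for weaker inhibition), gives 14 nM. Compound 2 `Cc1cc(S(C)(=O)=O)c(NC(=O)N(Cc2ccc(Oc3ccc(F)cc3)cc2)C2CCCCCC2)c(S(C)(=O)=O)n1` in this assay gives 45 nM. For the measured compounds named here, of the two numbers known so far, compound 1 has the lower one, and the gap to compound 2 is beyond the usual scatter, so compound 1 stands as the stronger of the two measured compounds.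

Compound 3 `Cc1cc(C)c(NC(=O)N(Cc2ccc(Oc3ccc(F)cc3)cc2)C2CCCCCC2)c(C)n1` is not yet measured. Its difference from compound 1 is a group of 9 heavy atoms (8 carbon, 1 nitrogen; one six-membered aromatic ring with 1 hetero atom) in place of a group of 9 heavy atoms (6 carbon, 1 nitrogen, 2 chlorine; one six-membered aromatic ring with 1 hetero atom), on an amide-type nitrogen, the entering group being 2,4,6-trimethylpyridin-3-yl on the amide-type nitrogen whose other neighbour is the carbonyl carbon. Going by the values given here, no measured pair shows an exchange of this kind, so there is no step to lean on; the expected change is small, with a slight lean towards a higher number, and most likely not beyond the scatter. Compound 3 is estimated at 20 nM, within 6 nM to 70 nM, which would mean an expected step of a 1.4-fold higher number from compound 1 to compound 3 (0.15 log units; within the scatter) in this assay.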

Compound 3, half-maximal inhibitory concentration: 62 nM
Compound 3: middle estimate off by 3.1-fold (0.49 log units), on the low side; low and high end bracket the measured number.
By their numbers in this assay, from the lowest: compound 1; then compounds 2 and 3 (each within the scatter of the next).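

The exchange of the group on the amide-type nitrogen for 2,4,6-trimethylpyridin-3-yl gives in this assay a 4.4-fold higher number from compound 1 to compound 3 (0.65 log units; beyond the scatter), so this position responds to a change that leaves the heavy-atom count and the six-membered aromatic ring as they were. Compound 2 at 45 nM and compound 3 at 62 nM lie within the scatter of each other, which leaves compound 1 alone with the lowest number of the three. Nothing measured here bears on the reason for this step.

Going by these compounds, how methoxy, trifluoromethyl or nitrile groups would fare on this ring in place of the chlorines stays open. Also open, on these data alone, is whether the step would keep its size with a change elsewhere in the shared core, since all three compounds carry that core unchanged.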